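Amide aryl swaps on the naphthalene-thiazolidinedione ether series

The source may hold more compounds than are shown below. What is called first, only, known or untested is meant among the compounds shown, and "the series" means these compounds.

Three compounds share one core and differ at the amide-type nitrogen. Compound 1 `Cc1cccc(NC(=O)COc2ccc3cc(/C=C4/SC(=O)NC4=O)ccc3c2)n1` gives 1100 nM in an assay on isolated protein for inhibition of histone deacetylase 4 (Homo sapiens), with a stated time of 1 h; on this read-out lower numbers stand for stronger inhibition and higher numbers for weaker inhibition; compound 2 `COc1cccc(NC(=O)COc2ccc3cc(/C=C4/SC(=O)NC4=O)ccc3c2)c1` gives 1600 nM; compound 3 `CCOc1ccc2nc(NC(=O)COc3ccc4cc(/C=C5/SC(=O)NC5=O)ccc4c3)sc2c1` gives 3600 nM. On these numbers compound 2 stands second highest of three, nearest compound 1 and furthest from compound 3. For the measured compounds named here, the one measured single-point step, a 1.5-fold higher number from compound 1 to compound 2 (0.16 log units; within the scatter), lies within the scatter.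

Compound 4 `O=C(COc1ccc2cc(/C=C3/SC(=O)NC3=O)ccc2c1)Nc1ccc([N+](=O)[O-])cc1` carries 4-nitrophenyl in place of 3-methoxyphenyl on an amide-type nitrogen. Going by the values given here, no measured step covers this change, and the only related step, a 1.5-fold higher number from compound 1 to compound 2 (0.16 log units; within the scatter), is flat, so no movement beyond the scatter is expected in this assay. Compound 4 is therefore estimated at 1600 nM, within 700 nM to 3600 nM, an expected step of no change at the digits printed from compound 2 to compound 4 (within the scatter).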

Compound 4, half-maximal inhibitory concentration: 1700 nM
Beside the measured number, compound 4's estimate is 1.1-fold (0.03 log units) below it; measured number inside the range.
By their numbers in this assay, from the lowest: compounds 1, 2 and 4 (each within the scatter of the next); then compound 3.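

In this assay, replacing 3-methoxyphenyl with 4-nitrophenyl on the amide-type nitrogen gives a 1.1-fold higher number from compound 2 to compound 4 (0.03 log units; within the scatter), and replacing 6-methylpyridin-2-yl with it gives a 1.5-fold higher number from compound 1 to compound 4 (0.19 log units; within the scatter). For the compounds shown here, the flat reading at this position therefore now spans three aryl groups, not two, while compound 3 remains the only member set apart from compound 2 by a gap beyond the scatter. No evidence bears on this flat result.

The step from compound 2 to compound 4 changes both the substituent and its printed ring number, so the two changes cannot be separated. As far as these compounds go, whether a carboxylic acid or an amine on the phenyl ring, or a longer chain in its place, would move the number remains open.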